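Replacing naphthalen-1-yl with 4-chlorophenyl in compound 1

The source may report more compounds than this note shows. Statements on the series, on what has been measured and on what is new or still open speak of the compounds shown alone.

In an ADME assay on HEK-293T cells (Homo sapiens) for inhibition, read by CCK-8 assay, with a stated time of 48 h, tested at 20 uM (a lower number here means less inhibition of growth, a higher number more inhibition of growth at the concentration tested), compound 1 `Cc1ccc(S(=O)(=O)Oc2ccccc2/C=C(\C#N)C(=O)Nc2nnc(Cc3cccc4ccccc34)s2)cc1` gives 23% and compound 3 `N#C/C(=C\c1ccccc1OS(=O)(=O)c1ccc(Cl)cc1)C(=O)Nc1nnc(Cc2cccc3ccccc23)s1` gives 16%. Among the compounds with values here, these are the only two numbers available, and they lie within the scatter of each other. Compound 2 `N#C/C(=C\c1ccccc1OS(=O)(=O)c1ccccc1[N+](=O)[O-])C(=O)Nc1nnc(Cc2cccc3ccccc23)s1` is recorded only as "not toxic" (no number reported), so it cannot be placed on the scale. Compound 4 `Cc1ccc(S(=O)(=O)Oc2ccccc2/C=C(\C#N)C(=O)Nc2nnc(Cc3ccc(Cl)cc3)s2)cc1` has not yet been measured. It departs from compound 1 by 4-chlorophenyl in place of naphthalen-1-yl on a saturated chain carbon bound to an aromatic carbon. The same difference can be read as (naphthalen-1-yl)methyl to 4-chlorobenzyl.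

Within the data shown here, only one measured step offers any guidance: a number 7 percentage points lower from compound 1 to compound 3 (within the scatter). That step is chloro in place of methyl on an aromatic carbon, and it leaves the naphthalen-1-yl group untouched. Among the measured compounds shown here, no measured compound shows what happens when that group is replaced, so the evidence is indirect and no direction is firmly indicated. The expected result is a number 3 percentage points lower from compound 1 to compound 4 (within the scatter), with no shift beyond the scatter anticipated. For compound 4 the estimated value in this assay is 20%, with an expected range of 6% to 36%.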

Compound 4, percent growth inhibition at one concentration: 20%
Compound 4: the middle estimate sits on the measured number at the digits printed; measured number inside the range.
By their numbers in this assay, from the lowest: compounds 3, 4 and 1 (each within the scatter of the next).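

In this assay, the change at this position gives a number 3 percentage points lower from compound 1 to compound 4 (within the scatter). Within the data shown here, this is the first step in the set that touches the naphthalen-1-yl group, as the earlier compounds all carry it, and it shows that going from this two-ring group to the one-ring 4-chlorophenyl, on a saturated chain carbon bound to an aromatic carbon, brings no shift beyond the scatter in growth inhibition at the concentration tested. Nothing among the data given accounts for this result.

Both groups compared here are aromatic rings of carbon only, so the compounds shown leave open whether an amine or a carboxylic acid at this place would also stay within the scatter of compound 1. They also leave open whether a longer chain carrying the 4-chlorophenyl group would do the same.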